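Moving away from 2,4-dichlorophenyl on compound 2

The source may report more compounds than this note shows. Statements on the series, on what has been measured and on what is new or still open speak of the compounds shown alone.

Within the data shown here, in an ADME assay on MT4 cells (Homo sapiens) for cytotoxicity, read by MTT assay, with a stated time of 4 days (on this read-out lower numbers stand for higher toxicity in this test and higher numbers for lower toxicity in this test), compound 1 (`Cc1cccc(Oc2nc(Nc3ccc(C#N)cc3)nc3ccccc23)c1`) gives 355000 nM and compound 2 (`N#Cc1ccc(Nc2nc(Oc3ccc(Cl)cc3Cl)c3ccccc3n2)cc1`) gives 32000 nM as the lower of the two numbers so far. Compound 3 (`COc1cc(C#N)ccc1Oc1nc(Nc2ccc(C#N)cc2)nc2ccccc12`) carries 4-cyano-2-methoxyphenyl in place of 2,4-dichlorophenyl on an oxygen on an aromatic ring. Among the measured compounds shown here, the one measured step at this place is an 11-fold lower number from compound 1 to compound 2 (1.05 log units; beyond the scatter) on entry of 2,4-dichlorophenyl, a large step. For the measured compounds named here, compound 3 gives up that group, but the entering group has no measured precedent, so only part of that large step is expected to be reversed in this assay and the direction expected is toward a higher number. The expected change is a 2.8-fold higher number from compound 2 to compound 3 (0.45 log units; beyond the scatter) with wide uncertainty. For compound 3 the estimate is 90000 nM with an expected range from 20000 nM to 350000 nM on this read-out.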

Compound 3, half-maximal cytotoxic concentration: >= 140000 nM
Compound 3 ended at the assay's limit; the forecaster's own chance of this, stated with the estimate: 20%; at least 1.5-fold (0.19 log units) between middle value and limit.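

In this assay, moving away from 2,4-dichlorophenyl on the oxygen gives an at least 4.3-fold higher number from compound 2 to compound 3 (0.64 log units; beyond the scatter), so a second group, 4-cyano-2-methoxyphenyl, now reads higher than 2,4-dichlorophenyl, as 3-methylphenyl already did. Compound 3 stands at a limit of the assay, >= 140000 nM, which is not a number. The step from compound 1 to compound 3 cannot be read, and the rise at compound 3 is known only as a minimum: the limit of >= 140000 nM in this assay, at which 1 of the 3 values shown sits.

Going by these compounds, compound 3 brings in the nitrile and the methoxy together, so it remains open how either would read alone, or how a single chlorine would read on the same ring. Also open, on these data alone, is how a phenyl ring bearing a carboxylic acid or an amine would read in this assay.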